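A Second Chloro Group on the Ring of Compound 1

The source may report more compounds than this note shows. Statements on the series, on what has been measured and on what is new or still open speak of the compounds shown alone.

Compound 1 `O=C1NC(=S)/C(=C/c2ccccc2Cl)S1` is the lower of two numbers in a functional assay on HEp-2 cells (Homo sapiens) for cytotoxicity, read by MTT assay, with a stated time of 72 h, tested at 10 ug/mL (a higher number here means more inhibition of growth at the concentration tested, a lower number less inhibition of growth), where compound 1 gives 21.2%. Compound 2 `O=C1NC(=S)/C(=C/c2ccc(Cl)cc2Cl)S1` gives 24.8%, and the step of a number 3.6 percentage points higher from compound 1 to compound 2 (within the scatter) bears on the question at hand. Compound 3 `O=C1NC(=S)/C(=C/c2c(Cl)cccc2Cl)S1` differs from compound 1 by chloro in place of hydrogen on an aromatic carbon. Going by the values given here, the only measured step, adding chloro elsewhere on the same ring, stayed within the scatter, so no step beyond the scatter is expected here either. The expected step is a number 3.8 percentage points higher from compound 1 to compound 3 (within the scatter). Compound 3 is therefore estimated at 25%, within a range from 12% to 40%.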

Compound 3, percent growth inhibition at one concentration: 8.73%
Beside the measured number, compound 3's estimate is 16.3 percentage points above it; the measured number lies below the stated range.
By their numbers in this assay, from the lowest: compound 3; then compounds 1 and 2 (each within the scatter of the next).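

Chloro in place of hydrogen on an aromatic carbon can lower the number in this assay when it stands ortho to a group of 8 heavy atoms and meta to a chloro group: the result is a number 12.5 percentage points lower from compound 1 to compound 3 (beyond the scatter) (the same change elsewhere on the ring gave a number 3.6 percentage points higher from compound 1 to compound 2 (within the scatter)). Among these compounds, then, the outcome of this change depends on where it stands on the ring. Nothing available here explains the difference between the two places.

The compounds shown leave open whether a methyl, a methoxy or an amine at this same place would lower the number as chloro does.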